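The source may report more compounds than this note shows. Statements on the series, on what has been measured and on what is new or still open speak of the compounds shown alone.

Compound 1 `CC(=O)Nc1cc(-c2ccc(N(C)C(=O)c3c(F)cccc3Cl)c(N3CC4CC4C3)c2)n(C2CCC2)n1` gives 0.5 ug/mL in a physicochemical assay for solubility, measured as kinetic solubility; on this read-out higher numbers stand for higher solubility and lower numbers for lower solubility.
Compound 2 `CC(=O)Nc1cc(-c2cnc(N(C)C(=O)c3c(F)cccc3Cl)c(N3CC4CC4C3)c2)n(C(C)C)n1` gives 48 ug/mL in this assay.
Compound 3 `CC(=O)Nc1cc(-c2ccc(N(C)C(=O)c3c(Cl)cccc3Cl)c(N3CC4CC4C3)c2)n(C(C)C)n1` gives 0.8 ug/mL in this assay.

Of these three, compound 2 stands highest in this assay: its value lies well beyond the usual scatter above both compound 3 and compound 1, so it is the most soluble of the set. Compound 4 `CC(=O)Nc1cc(-c2cnc(N(C)C(=O)c3c(F)cccc3Cl)c(N3CCCCC3)c2)n(C(C)C)n1` has not been measured yet. It differs from compound 2 in one place: a group of 6 heavy atoms (5 carbon, 1 nitrogen; one six-membered non-aromatic ring with 1 hetero atom) in place of a group of 6 heavy atoms (5 carbon, 1 nitrogen; one three-membered non-aromatic ring of carbon only, one five-membered non-aromatic ring with 1 hetero atom), on an aromatic carbon. For the measured compounds named here, no pair of measured compounds differs in exactly this way, so no measured step speaks directly for it. The group that leaves and the group that enters have the same number of heavy atoms and the same count of hydrogen-bond donors and acceptors, and the rest of the structure is unchanged. The step from compound 2 to compound 4 in this assay is therefore expected to be small, probably within the scatter, with a slight lean toward a lower number. The estimate for compound 4 is 30 ug/mL, within a range from 8 ug/mL to 100 ug/mL, which corresponds to an expected step of a 1.6-fold lower number from compound 2 to compound 4 (0.20 log units; within the scatter).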

Compound 4, solubility: 37.4 ug/mL
Estimate against measurement, compound 4: 1.2-fold (0.10 log units) below; measured number inside the range.
By their numbers in this assay, from the lowest: compounds 1 and 3 (each within the scatter of the next); then compounds 4 and 2 (each within the scatter of the next).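

For the compounds shown here, the step at this position, on an aromatic carbon of a six-membered aromatic ring with 1 nitrogen, is the first that can be read in this assay: with piperidin-1-yl in place of the group holding the three-membered and five-membered rings, the result is a 1.3-fold lower number from compound 2 to compound 4 (0.11 log units; within the scatter), so the two compounds cannot be told apart. For this pair, then, the ring pattern can be exchanged at equal heavy-atom count without a step beyond the scatter. Nothing measured here explains this outcome.

Going by these compounds, what remains open is whether the same exchange would also leave the number within the scatter on the core of compound 3, which carries the group that leaves. On these data alone, it is also open how a ring containing oxygen, such as morpholin-4-yl, or an added amine would read at this position.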